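Amide variation on the shared core: benzamide without ring substituents

The source may report more compounds than this note shows. Statements on the series, on what has been measured and on what is new or still open speak of the compounds shown alone.

Three amide-linked analogues on the shared core have been run in a functional assay on UACC-62 cells (Homo sapiens) for inhibition, read by sulforhodamine B assay, with a stated time of 48 h; on this read-out higher numbers stand for weaker inhibition of growth and lower numbers for stronger inhibition of growth. Compound 1 `O=C(Nc1cccc(-n2cc(-c3ccncc3)c(-c3ccc(Cl)c(O)c3)n2)c1)Nc1cccc(C(F)(F)F)c1` gives 1650 nM in this assay. Compound 2 `COc1cc(-c2nn(-c3cccc(NC(=O)c4cccc(C(F)(F)F)c4)c3)cc2-c2ccncc2)ccc1Cl` gives 1940 nM in this assay. Compound 3 `COc1cc(-c2nn(-c3cccc(NC(=O)c4ccc(Cl)c(C(F)(F)F)c4)c3)cc2-c2ccncc2)ccc1Cl` gives 2100 nM in this assay, and its number lies within the scatter of both compound 2 and compound 1, so the three are not separated by these data.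

Compound 4 `COc1cc(-c2nn(-c3cccc(NC(=O)c4ccccc4)c3)cc2-c2ccncc2)ccc1Cl` differs from compound 3 by phenyl in place of 4-chloro-3-(trifluoromethyl)phenyl on a carbonyl carbon. Going by the values given here, the only measured step on this amide ring, a 1.1-fold higher number from compound 2 to compound 3 (0.03 log units; within the scatter), concerns the chloro alone and stayed within the scatter. Among the compounds with values here, no measured step removes the trifluoromethyl from this ring, so that part of the change is uncovered. On what is shown, the expected step in this assay is a 1.2-fold higher number from compound 3 to compound 4 (0.09 log units; within the scatter), with no confident direction beyond the scatter, and a modest lean toward a higher number that rests on nothing measured. Compound 4 is therefore estimated at 2600 nM in this assay, within 1200 nM to 6000 nM.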

Compound 4, concentration for 50% growth inhibition: 692 nM
Beside the measured number, compound 4's estimate is 3.8-fold (0.57 log units) above it, outside the stated range (below it).
By their numbers in this assay, from the lowest: compound 4; then compounds 1, 2 and 3 (each within the scatter of the next).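

In this assay, going by these compounds alone, the ring on the carbonyl carbon turns out to respond to substitution: hydrogen in place of trifluoromethyl gives a 2.8-fold lower number from compound 2 to compound 4 (0.45 log units; beyond the scatter) as the first step on this ring beyond the scatter. Phenyl in place of 4-chloro-3-(trifluoromethyl)phenyl gives a 3.0-fold lower number from compound 3 to compound 4 (0.48 log units; beyond the scatter) and reads the same way, whereas the chloro alone gave only a 1.1-fold higher number from compound 2 to compound 3 (0.03 log units; within the scatter) and stayed within the scatter. No evidence at hand accounts for the lower numbers once the trifluoromethyl is gone.

On these data alone, it remains open whether this lower number needs hydrogen itself or would hold with methyl, fluoro or methoxy in place of the trifluoromethyl. Also open, as far as these compounds go, are how an amine or a carboxylic acid on this ring would read, and whether the plain phenyl keeps its lower number with the linker of compound 1.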